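Notes on the step from compound 2 to compound 4

A few compounds are considered here, and "the series" means these few. Any claim that something is new, unique, unknown or untested is made for them only; others in the source may bear on it.

Measured in a functional assay on QG-56 cells (Homo sapiens) for antiproliferative activity; a lower number here means a stronger inhibitor, a higher number a weaker inhibitor:
- compound 1 `Cn1cncc1C(O)(c1ccc([N+](=O)[O-])cc1)c1cc2cc([N+](=O)[O-])cc(-c3ccccc3)c2o1`: 547 nM
- compound 2 `COc1cccc(-c2cc([N+](=O)[O-])cc3cc(C(O)(c4ccc(C#N)cc4)c4cncn4C)oc23)c1`: 38.8 nM
- compound 3 `COc1ccc(C(O)(c2cc3cc([N+](=O)[O-])cc(-c4ccccc4)c3o2)c2cncn2C)cc1`: 4970 nM

Compound 2, at 38.8 nM, has the lowest number of the three in this assay, and the gaps to compound 1 and compound 3 both lie beyond the scatter. The next compound is compound 4 `Cn1cncc1C(O)(c1ccc(C#N)cc1)c1cc2cc([N+](=O)[O-])cc(-c3ccc(C#N)cc3)c2o1`, in which 4-cyanophenyl stands in place of 3-methoxyphenyl: 4-cyanophenyl in place of 3-methoxyphenyl on an aromatic carbon. Within the data shown here, the only measured step is a 9.1-fold higher number from compound 1 to compound 3 (0.96 log units; beyond the scatter), a modest one with methoxy in place of nitro. That step lies at a different place, so it shows only that one aromatic substitution in this series can move the number beyond the scatter. Among the measured compounds shown here, no measured step covers the place changed here, which leaves the direction open. A slight rise is assumed, since compound 2 at 38.8 nM is already the lowest value. The expected change is small, a 1.5-fold higher number from compound 2 to compound 4 (0.19 log units; within the scatter), with a wide margin. For compound 4 the estimated value is 60 nM, with an expected range of 15 nM to 250 nM.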

Compound 4, half-maximal inhibitory concentration: 32.6 nM
The estimate for compound 4 lay 1.8-fold (0.26 log units) above the measured number; the measured number falls inside the stated range.
By their numbers in this assay, from the lowest: compounds 4 and 2 (each within the scatter of the next); then compound 1; then compound 3.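

In this assay, the exchange of 3-methoxyphenyl for 4-cyanophenyl on the aromatic carbon meta to a nitro group gives a 1.2-fold lower number from compound 2 to compound 4 (0.08 log units; within the scatter). Among these compounds, this is the first reading at this place, as the earlier step, a 9.1-fold higher number from compound 1 to compound 3 (0.96 log units; beyond the scatter), lay elsewhere; here, two aryl groups with the same heavy-atom count give numbers within the scatter of each other. Nothing available explains why the two groups read alike.

The compounds shown carry only phenyl rings at this place, so a morpholine or a carboxylic acid there remains open. Also open, as far as these compounds go, are the separate contributions of the methoxy and nitrile groups, since this one step changes both the substituent and its place on the ring.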